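Swapping fluoro for dimethylamino on the aromatic carbon

This account rests on a few compounds, and the source may have more. Where it says the series, first, only, none or still open, it means among the compounds named here.

In a functional assay on WM164 cells (Homo sapiens) for antiproliferative activity, read by sulforhodamine B assay, with a stated time of 48 h (on this read-out lower numbers stand for stronger inhibition and higher numbers for weaker inhibition), compound 2 (`CN(C)c1ccc2c(c1)OC(N)=C(C#N)C2c1ccc(F)c2ccccc12`) gives 470 nM. That places it level, within the scatter, with compound 1 (`COc1ccc(C2C(C#N)=C(N)Oc3cc(N(C)C)ccc32)c2ccccc12`) at 490 nM. Compound 3 (`CN(C)c1ccc2c(c1)OC(N)=C(C#N)C2c1ccc(N(C)C)c2ccccc12`) carries dimethylamino in place of fluoro on an aromatic carbon, para to a large group: dimethylamino in place of fluoro on an aromatic carbon. Among the measured compounds shown here, the only measured step at this carbon, a 1.0-fold lower number from compound 1 to compound 2 (0.02 log units; within the scatter), stayed within the scatter, so no change beyond the scatter is expected, although this rests on a single step and dimethylamino itself is untested. The expected step is a 1.0-fold lower number from compound 2 to compound 3 (0.02 log units; within the scatter). Compound 3 is estimated at 450 nM, with an expected range of 150 nM to 1400 nM.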

Compound 3, half-maximal inhibitory concentration: 160 nM
Compound 3: the middle estimate sits 2.8-fold (0.45 log units) above what was measured; the measured number falls inside the stated range.
By their numbers in this assay, from the lowest: compound 3; then compounds 2 and 1 (each within the scatter of the next).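

At this aromatic carbon, para to a large group, the choice of group does change the number in this assay, which the earlier pair of compounds did not show. Dimethylamino gives a 2.9-fold lower number from compound 2 to compound 3 (0.47 log units; beyond the scatter), and in place of methoxy it gives a 3.1-fold lower number from compound 1 to compound 3 (0.49 log units; beyond the scatter). Nothing measured here accounts for this difference. The compounds shown leave open whether another amine at this carbon, such as a primary amine, diethylamino or morpholine, would give a similarly low number, or whether the step belongs to dimethylamino alone.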